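Swapping tert-butyl for neopentyl on a second core

The compounds below may be only part of what the source reports. "The series", "measured", "known", "first", "only" and "open" are said of these compounds alone.

Compound 1 `CC(C)(C)[C@@H](O)C(=O)N1C[C@@H]2C[C@@H]2[C@H]1C(=O)NCc1cc(Cl)ccc1-n1cnnn1` and compound 2 `CC(C)(C)C[C@@H](O)C(=O)N1C[C@@H]2C[C@@H]2[C@H]1C(=O)NCc1cc(Cl)ccc1-n1cnnn1` share one core, while compound 3 `CC(C)(C)[C@@H](O)C(=O)N1NCC[C@H]1C(=O)NCc1cc(Cl)ccc1-n1cnnn1` and the not yet measured compound 4 `CC(C)(C)C[C@@H](O)C(=O)N1NCC[C@H]1C(=O)NCc1cc(Cl)ccc1-n1cnnn1` share another; the difference between the two cores is not broken down here. In an ADME assay on Caco-2 cells (Homo sapiens) for permeability, read by LC-MS, in the apical to basolateral direction, with a stated time of 60 min, at pH 6.5 (on this read-out lower numbers stand for lower permeability and higher numbers for higher permeability), compound 1 gives 17 10^-6 cm/s and compound 2 gives 25 10^-6 cm/s. The change between them is neopentyl in place of tert-butyl on a saturated chain carbon bound to a carbonyl carbon and an oxygen on a saturated carbon, and it made a step of a 1.5-fold higher number from compound 1 to compound 2 (0.17 log units; within the scatter). In this assay compound 3 gives 7.2 10^-6 cm/s, the lowest of the three numbers. The same change, (neopentyl in place of tert-butyl on a saturated chain carbon bound to a carbonyl carbon and an oxygen on a saturated carbon), is made from compound 3 to compound 4. Because the earlier step was a 1.5-fold higher number from compound 1 to compound 2 (0.17 log units; within the scatter), a step of about the same size in this assay, a 1.5-fold higher number from compound 3 to compound 4 (0.18 log units; within the scatter), is expected here. Compound 4 is therefore expected to give about 11 10^-6 cm/s, most likely between 6 10^-6 cm/s and 20 10^-6 cm/s.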

Compound 4, apparent permeability: 15 10^-6 cm/s
Compound 4: middle estimate off by 1.4-fold (0.13 log units), on the low side; the measured number falls inside the stated range.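

In this assay, neopentyl in place of tert-butyl gives a 2.1-fold higher number from compound 3 to compound 4 (0.32 log units; beyond the scatter). Both steps go the same way, and the two cores carry the change about equally: the same change on two cores in this assay, a 1.5-fold higher number (0.17 log units; within the scatter) from compound 1 to compound 2 and a 2.1-fold higher number (0.32 log units; beyond the scatter) from compound 3 to compound 4, 1.4-fold (0.15 log units) apart, within the scatter of two such steps

For the compounds shown here, this is only one pair of compounds on each of two cores, so it does not show that the step would hold on any other core, and it does not explain why the number rises.

The compounds shown leave open what a longer chain or an amine at this place would do to the number. They also leave open whether the neopentyl step would keep its size in other assays.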